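Swapping the aryl group on a piperazine nitrogen

The source may hold more compounds than are shown below. What is called first, only, known or untested is meant among the compounds shown, and "the series" means these compounds.

Compound 1 `CCCc1nc(-c2ccccc2)c(CNCCCN2CCN(c3cccc(OC)c3)CC2)o1`: 36.4%
Compound 2 `CCCc1nc(-c2ccccc2)c(CNCCN2CCN(c3ccccc3Cl)CC2)o1`: 60.1%
Compound 3 `CCCc1nc(-c2ccccc2)c(CNCCCN2CCN(c3ccccc3F)CC2)o1`: 54.4%

In an assay on HEK293 cells for inhibition of Voltage-dependent T-type calcium channel subunit alpha-1G (Homo sapiens), read by fluorescence, tested at 10 uM (a higher number here means more inhibition at the concentration tested (going by the name of the read-out), a lower number less inhibition), compound 2 gives the highest of the three numbers; compound 3 lies within the scatter of it, while compound 1 lies beyond the scatter below it. Compound 4 `CCCc1nc(-c2ccccc2)c(CNCCN2CCN(c3ccccn3)CC2)o1` differs from compound 2 in one place: pyridin-2-yl in place of 2-chlorophenyl on an amine nitrogen in a ring. Among the measured compounds shown here, the only measured step that changes the group on that ring nitrogen is a number 18 percentage points higher from compound 1 to compound 3 (beyond the scatter), a modest shift. For the measured compounds named here, no measured pair shows pyridin-2-yl itself, so the direction is uncertain; a step of similar modest size is expected, leaning lower. For compound 4 the expected value is 48% (range 25% to 70%), an estimated step of a number 12.1 percentage points lower from compound 2 to compound 4 (beyond the scatter).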

Compound 4, a percentage reported as inhibition, at one concentration (the size of the read-out at that concentration, not a potency): 48.1%
Compound 4: the middle estimate sits 0.1 percentage points below what was measured; the range from low to high includes it.
By their numbers in this assay, from the lowest: compound 1; then compounds 4, 3 and 2 (each within the scatter of the next, the first and the last beyond it).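

In this assay, replacing the carbon-only ring on the piperazine nitrogen with a ring holding a nitrogen gives a number 12 percentage points lower from compound 2 to compound 4 (beyond the scatter), so this position responds to a change in the ring itself, not only to a change in what the ring carries. With the earlier step from compound 1 to compound 3, the group on this nitrogen has now moved the number in both directions. No measurement here explains this fall. The compounds shown leave open whether it follows the loss of chlorine or the gain of the ring nitrogen; a plain phenyl group on this nitrogen would separate the two.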